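Notes on a benzimidazole-type series: compound 1 to compound 4

The source may report more compounds than this note shows. Statements on the series, on what has been measured and on what is new or still open speak of the compounds shown alone.

Measured compounds:
Compound 1 `CC(=O)Nc1ccc2[nH]c(C)nc2c1`: 1260000 nM
Compound 2 `CCCCC(=O)Nc1ccc2[nH]c(C)nc2c1`: 417000 nM
Compound 3 `O=[N+]([O-])c1cc(Cl)cc2[nH]cnc12`: 129000 nM

In an ADME assay on microsomes from liver for inhibition of cytochrome P450 2B1 (Rattus norvegicus) (on this read-out lower numbers stand for stronger inhibition and higher numbers for weaker inhibition), compound 1 gives 1260000 nM, the highest of the three numbers; compound 2 at 417000 nM is nearest, compound 3 at 129000 nM furthest. Compound 4 `Cc1ccc2[nH]c(C)nc2c1` is not yet measured. It differs from compound 1 by methyl in place of acetamido on an aromatic carbon, a methyl in place of acetamido on an aromatic carbon of the shared core.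

Among the measured compounds shown here, the one step that bears on this change is a 3.0-fold lower number from compound 1 to compound 2 (0.48 log units; beyond the scatter), which lengthens the chain on the acetamido carbonyl and lowers the number modestly. For the measured compounds named here, compound 3 carries no acetamido at all and shows the lowest number, but no single-point step connects it to compound 1, so it only hints at the direction. Removing the acetamido entirely is a larger change than extending it; a modest lowering of the number is therefore expected, in the direction of compound 2, with wide uncertainty. For compound 4 the estimated value is 700000 nM, range 200000 nM to 2500000 nM, corresponding to an expected step of a 1.8-fold lower number from compound 1 to compound 4 (0.26 log units; within the scatter).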

Compound 4, half-maximal inhibitory concentration: 479000 nM
For compound 4 the middle estimate is 1.5-fold (0.16 log units) above the measured one; the range from low to high includes it.
By their numbers in this assay, from the lowest: compound 3; then compounds 2 and 4 (each within the scatter of the next); then compound 1.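

In this assay, the number does not depend on keeping the acetamido group on this aromatic carbon: methyl in its place gives a 2.6-fold lower number from compound 1 to compound 4 (0.42 log units; beyond the scatter). Together with a 3.0-fold lower number from compound 1 to compound 2 (0.48 log units; beyond the scatter), this shows that two opposite changes at this position, lengthening the chain on the carbonyl and removing the acetamido altogether, both lower the number. Compound 2 at 417000 nM and compound 4 at 479000 nM lie within the scatter of each other, so the size of the group here does not separate these two compounds. No measurement at hand accounts for this result. Open, as far as these compounds go, is how an amine or a carboxylic acid on this aromatic carbon would read against compound 4. Also open, from the compounds shown here alone, is whether a longer chain on the carbonyl would carry the number beyond compound 2.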